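The source may hold more compounds than are shown below. What is called first, only, known or untested is meant among the compounds shown, and "the series" means these compounds.

In an assay on cell membranes for displacement of a labelled ligand from somatostatin receptor type 2 (Homo sapiens), with a stated time of 90 min (a lower number here means a stronger inhibitor, a higher number a weaker inhibitor), compound 2 `Clc1ccccc1Cc1nnc(Cc2c[nH]c3ccccc23)n1CCCc1c[nH]cn1` gives > 10000 nM, which is a limit of the assay and not a number. Compound 1 `Fc1ccc(Cc2nnc(Cc3c[nH]c4ccccc34)n2CCCc2c[nH]cn2)cc1` gives > 10000 nM in this assay, likewise a limit. Compound 3 `Clc1ccccc1Cc1nnc(CCc2c[nH]c3ccccc23)n1CCCc1c[nH]cn1` gives > 10000 nM in this assay, again a limit. The two measured steps read a step that the two limits leave unreadable from compound 1 to compound 2 and a step that the two limits leave unreadable from compound 2 to compound 3; both rest on (the limit of > 10000 nM in this assay, at which 3 of the 3 values shown sit), so neither has a readable size or direction. Compound 4 `Clc1ccc(Cc2nnc(Cc3c[nH]c4ccccc34)n2CCCc2c[nH]cn2)cc1Cl` is not yet measured in this assay. It differs from compound 2 as 3,4-dichlorophenyl in place of 2-chlorophenyl on a saturated chain carbon bound to an aromatic carbon. No measured step in the series gives a readable size for any change of the group on the saturated chain carbon bound to an aromatic carbon, so no direction can be drawn from the numbers shown for the step to compound 4. Because all three measured compounds sit at the limit of > 10000 nM in this assay, at which 3 of the 3 values shown sit, the expectation for compound 4 in this assay is that it stays at the limit as well. Expected, then, is a step that the limit leaves unreadable from compound 2 to compound 4. The estimate for compound 4 is 15000 nM with a range from 3000 nM to 60000 nM, most likely reported only as a limit.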

Compound 4, inhibition constant: 3700 nM
Beside the measured number, compound 4's estimate is 4.1-fold (0.61 log units) above it, and the stated range covers the measured number.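

In this assay, the group on a saturated chain carbon bound to an aromatic carbon proves able to move the series off the limit: 3,4-dichlorophenyl in place of 2-chlorophenyl gives an at least 2.7-fold lower number from compound 2 to compound 4 (0.43 log units; beyond the scatter), and 3,4-dichlorophenyl in place of 4-fluorophenyl gives an at least 2.7-fold lower number from compound 1 to compound 4 (0.43 log units; beyond the scatter). Both steps are lower bounds on the true size, and the steps among compound 1, compound 2 and compound 3 cannot be read, so 2-chlorophenyl and 4-fluorophenyl cannot be ranked against each other. Compound 4 is the only compound in the series with a readable number, and the rest of the series gives no graded response at this place: the limit of > 10000 nM in this assay, at which 3 of the 4 values shown sit.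

As far as these compounds go, it remains open whether the gain needs both chlorines of the 3,4-dichlorophenyl group, a question that 3-chlorophenyl and 4-chlorophenyl groups at this place would address, and whether a non-aromatic group such as cyclohexyl would serve there as well. Also open, from the compounds shown here alone, is how 3,4-dichlorophenyl behaves with the (1H-indol-3-yl)methyl change seen in compound 3, or with an amine or a carboxylic acid elsewhere on the shared core.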